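Replacing the carboxy group of compound 2 with methyl

This account rests on a few compounds, and the source may have more. Where it says the series, first, only, none or still open, it means among the compounds named here.

In a functional assay on HL-60 cells (Homo sapiens) for antiproliferative activity, with a stated time of 72 h (on this read-out lower numbers stand for stronger inhibition and higher numbers for weaker inhibition), compound 2 (`COc1cc(OC)c(C(=O)/C=C/c2ccccc2Cl)c(O)c1CN(C)CC(=O)O`) gives 80300 nM as the higher of the two numbers available. Going by the values given here, the only other measured compound is compound 1 (`COC(=O)CN(C)Cc1c(OC)cc(OC)c(C(=O)/C=C/c2ccccc2Cl)c1O`), which gives 400 nM in this assay and stands far lower. Among the compounds with values here, the one measured step of a 200-fold higher number from compound 1 to compound 2 (2.30 log units; beyond the scatter) is large and beyond the scatter, and it is the step that exposes the free carboxy group. Compound 3 (`CCN(C)Cc1c(OC)cc(OC)c(C(=O)/C=C/c2ccccc2Cl)c1O`) removes that group altogether (methyl in place of carboxy on a saturated chain carbon bound to an amine nitrogen), with methyl in place of carboxy on a saturated chain carbon bound to an amine nitrogen. Neither compound 3 nor compound 1 at 400 nM has a free carboxy group, so most of that large step is expected to be reversed, though one step is thin support. The expected change is a 110-fold lower number from compound 2 to compound 3 (2.06 log units; beyond the scatter) in this assay as a large move to a lower number. Compound 3 is estimated at 700 nM with a range from 150 nM to 4000 nM overall.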

Compound 3, half-maximal inhibitory concentration: 200 nM
Compound 3: middle estimate off by 3.5-fold (0.54 log units), on the high side; the range from low to high includes it.
By their numbers in this assay, from the lowest: compounds 3 and 1 (each within the scatter of the next); then compound 2.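

In this assay methyl in place of carboxy on a saturated chain carbon bound to an amine nitrogen gives a 400-fold lower number from compound 2 to compound 3 (2.60 log units; beyond the scatter) and so ties the high number of compound 2 to the carboxy group itself, since this second step out of that compound reaches the same level by another replacement. At the same place, methyl in place of methoxycarbonyl gives a 2.0-fold lower number from compound 1 to compound 3 (0.30 log units; within the scatter) and leaves no difference that can be told apart between the ethyl end of compound 3 and the ester end of compound 1. Nothing available on other properties of these compounds speaks to why the carboxy group goes with the high number.

As far as these compounds go, whether a primary amide, a hydroxymethyl group or a longer chain at this place would stay at the level of compound 1 and compound 3 remains open. Also open, from the compounds shown here alone, is how a piperidine in place of the ethyl(methyl)amino group would read in this assay.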